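The source may report more compounds than this note shows. Statements on the series, on what has been measured and on what is new or still open speak of the compounds shown alone.

Compound 1 `N[C@H]1CC[C@H](Nc2c(C(=O)NCc3ccco3)nc(Br)c3cccnc23)CC1` carries an amide bearing a furan-derived chain on the shared core. In a functional assay on HCT-116 cells (Homo sapiens) for cytotoxicity, read by MTT assay, with a stated time of 72 h (a lower number here means a stronger inhibitor, a higher number a weaker inhibitor), compound 1 gives only a limit, > 10000 nM, and no number. Compound 2 `COC(=O)c1nc(Br)c2cccnc2c1N[C@H]1CC[C@H](N)CC1` is the methyl ester of the same core, and for compound 2 the outcome in this assay is "not determined" (no result reported). So compound 2 stands nowhere on the numbers: the only measured value in this small set is the limit described by the limit of > 10000 nM in this assay, at which 1 of the 2 values shown sits, and no measured step exists to calibrate the change in this assay.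

Compound 3 `COc1ccc(CNC(=O)c2nc(Br)c3cccnc3c2N[C@H]2CC[C@H](N)CC2)cc1` differs from compound 2 by (4-methoxybenzyl)amino in place of methoxy on a carbonyl carbon. Within the data shown here, with no measured step, the size and direction of the effect in this assay cannot be read from these data; the nearest measured neighbour is compound 1, an amide that sits at the limit. Compound 3 is therefore expected to land near that same region, estimated at 15000 nM with a range from 4000 nM to 60000 nM.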

Compound 3, half-maximal inhibitory concentration: 3000 nM
Compound 3: middle estimate off by 5.0-fold (0.70 log units), on the high side, and the stated range ends above it.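

Replacing furan-2-yl with 4-methoxyphenyl on the saturated chain carbon bound to an amide-type nitrogen gives an at least 3.3-fold lower number from compound 1 to compound 3 (0.52 log units; beyond the scatter) in this assay, so the first measured number shows that cytotoxicity responds to the group at the end of this chain. The size of that step is only a lower bound because compound 1 has a limit and no number: the limit of > 10000 nM in this assay, at which 1 of the 3 values shown sits. Compound 2 has no reported result, so the step from its methoxy to the (4-methoxybenzyl)amino group of compound 3 cannot be read.

From the compounds shown here alone, it remains open whether the methoxy on the ring of compound 3 contributes to the change, or whether a plain phenyl on the same chain would give a similar number. Going by these compounds, how a carboxylic acid on the same carbonyl carbon would behave in this assay also stays open.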